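This account rests on a few compounds, and the source may have more. Where it says the series, first, only, none or still open, it means among the compounds named here.

Of the compounds shown here, three sharing one core have been measured in a functional assay, tested at 400 ug/mL; a higher number here means a stronger effect of the compound at the concentration tested, a lower number a weaker effect. Compound 1 `N#CC1=C(N)OC(c2c[nH]c3ccccc23)=C(C#N)C1c1ccc(Br)cc1` gives 22.7%, compound 2 `COc1ccc(C2C(C#N)=C(N)OC(c3c[nH]c4ccccc34)=C2C#N)cc1OC` gives 28.1%, and compound 3 `N#CC1=C(N)OC(c2c[nH]c3ccccc23)=C(C#N)C1c1ccc(F)cc1` gives 26.7%. On these numbers compound 3 stands second highest of the three, with compound 2 nearest and compound 1 furthest. Both of those gaps lie within the scatter: a number 1.4 percentage points lower from compound 2 to compound 3 (within the scatter) and a number 4 percentage points higher from compound 1 to compound 3 (within the scatter).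

Compound 4 `N#CC1=C(N)OC(c2c[nH]c3ccccc23)=C(C#N)C1c1ccccc1` has not yet been measured. It differs from compound 3 in one place: hydrogen in place of fluoro on an aromatic carbon. The measured step that bears most directly on this change is the one at the same aromatic carbon, a number 4 percentage points higher from compound 1 to compound 3 (within the scatter), where fluoro in place of bromo moved the read-out only within the scatter. The broader exchanges of the whole group on the saturated ring carbon, a number 5.4 percentage points higher from compound 1 to compound 2 (within the scatter) and a number 1.4 percentage points lower from compound 2 to compound 3 (within the scatter), likewise stayed within the scatter. Nothing among these steps points to a shift beyond the scatter when hydrogen takes the place of fluoro, so the expected step is a number 1.7 percentage points lower from compound 3 to compound 4 (within the scatter), which is expected to remain within the scatter. In this assay compound 4 is therefore estimated at 25%, with an expected range from 15% to 35%.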

Compound 4, a percentage reported as activity, at one concentration (the size of the read-out at that concentration, not a potency): 26.7%
The estimate for compound 4 lay 1.7 percentage points below the measured number; low and high end bracket the measured number.
By their numbers in this assay, from the lowest: compounds 1, 3, 4 and 2 (each within the scatter of the next).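

In this assay, taking the fluoro off the aromatic carbon para to a large group altogether gives no change at the digits printed from compound 3 to compound 4 (within the scatter), so this position has now been seen with no substituent as well as with one halogen exchanged for another. The phenyl of compound 4 also stays within the scatter of the other two aryl groups: hydrogen in place of bromo gives a number 4 percentage points higher from compound 1 to compound 4 (within the scatter), and phenyl in place of 3,4-dimethoxyphenyl gives a number 1.4 percentage points lower from compound 2 to compound 4 (within the scatter), so none of the four groups shown on the saturated ring carbon separates from the others in this read-out. Nothing measured here accounts for this flat picture.

As far as these compounds go, whether an amine, a carboxylic acid or a longer chain on this phenyl would move the number beyond the scatter remains open, and so does the effect of exchanging a nitrile on the shared core for an amide. For the compounds shown here, with only one concentration behind each number, these compounds also leave open whether they would still read alike at other concentrations.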